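This account rests on a few compounds, and the source may have more. Where it says the series, first, only, none or still open, it means among the compounds named here.

Of the compounds shown here, two sharing one core have been measured in an in vitro ADME assay on microsomes from liver (Mus musculus) for pharmacokinetics, read by LC-MS, with a stated time of 10 min, tested at 1 uM; on this read-out lower numbers stand for slow clearance and higher numbers for fast clearance. Compound 1 `CN1C[C@H](C(=O)Nc2ccc(Cl)c(Cl)c2)[C@@H](c2ccc(/C=C/C(=O)Nc3ccccc3N)cc2)C1` gives 36 mL/min/kg, and compound 2 `CN1C[C@H](C(=O)Nc2ccc(Cl)cc2F)[C@@H](c2ccc(/C=C/C(=O)Nc3ccccc3N)cc2)C1` gives 43 mL/min/kg. These two numbers lie within the usual scatter of each other, so compound 2 stands level with compound 1. Compound 3 `CN1C[C@H](C(=O)Nc2ccc(Cl)cn2)[C@@H](c2ccc(/C=C/C(=O)Nc3ccccc3N)cc2)C1` changes the group on the amide-type nitrogen: 5-chloropyridin-2-yl in place of 4-chloro-2-fluorophenyl on an amide-type nitrogen. Going by the values given here, only one measured step bears on this place, a 1.2-fold higher number from compound 1 to compound 2 (0.08 log units; within the scatter), and it stayed within the scatter. On these data alone, that step offers limited guidance, since neither measured compound has a hetero atom in this ring, so the effect of adding one is untested. The expected result is therefore a small move, a 1.1-fold lower number from compound 2 to compound 3 (0.05 log units; within the scatter), with no step beyond the scatter anticipated. The estimated clearance of compound 3 is 38 mL/min/kg, with an expected range from 20 mL/min/kg to 70 mL/min/kg.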

Compound 3, clearance: 31 mL/min/kg
The estimate for compound 3 lay 1.2-fold (0.09 log units) above the measured number; low and high end bracket the measured number.
By their numbers in this assay, from the lowest: compounds 3, 1 and 2 (each within the scatter of the next).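

In this assay the ring on the amide-type nitrogen can carry a hetero atom with clearance staying level: a 1.4-fold lower number from compound 2 to compound 3 (0.14 log units; within the scatter) and a 1.2-fold lower number from compound 1 to compound 3 (0.06 log units; within the scatter) both lie within the scatter. Going by these compounds alone, compound 1 and compound 2 both had a ring of carbon only at this place, so 5-chloropyridin-2-yl gives the first reading of a ring with a hetero atom and a hydrogen-bond acceptor here. No measurement at hand offers an explanation for this result.

On these data alone, all three groups are six-membered aromatic rings bearing chlorine, so it stays open whether clearance would hold with a ring lacking chlorine, such as plain pyridin-2-yl. As far as these compounds go, it also stays open what a group of a different kind at this place would do, such as a carboxylic acid or a saturated amine like piperidine.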